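A few compounds are considered here, and "the series" means these few. Any claim that something is new, unique, unknown or untested is made for them only; others in the source may bear on it.

Measured compounds:
- compound 1, `Clc1ccc2c(NCCNc3nccc(Nc4ccccc4)n3)ccnc2c1`: in an ADME assay on Vero cells (Chlorocebus sabaeus) for cytotoxicity, read by neutral red uptake, with a stated time of 72 h (a higher number here means a weaker inhibitor, a lower number a stronger inhibitor), compound 1 is reported as "not active" (no number reported)
- compound 2, `Cc1ccc(Nc2ccnc(NCCNc3ccnc4cc(Cl)ccc34)n2)cc1`: in this assay compound 2 gives 13600 nM

Compound 1 thus has no single number in this assay; only compound 2 carries a value, and it sits at a high concentration, which points to weak cell toxicity. The unmeasured compound 3, `COc1cc(Nc2ccnc(NCCNc3ccnc4cc(Cl)ccc34)n2)cc(OC)c1`, differs from compound 1 by one change: 3,5-dimethoxyphenyl in place of phenyl on a nitrogen on an aromatic ring. Among the measured compounds shown here, no step between two measured compounds is available to size this change, and the shared core is kept. On these numbers, a step from compound 1 to compound 3 is expected to be small or none beyond the scatter, staying in the weak range that compound 2 also shows with 13600 nM. Compound 3 is therefore expected to give about 15000 nM in this assay, within roughly 5000 nM to 50000 nM, with a real chance that only a limit is reported.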

Compound 3, half-maximal inhibitory concentration: "not active" (no number reported)
No number was reported for compound 3; there is nothing to compare the estimate with.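

In this assay neither compound 1 nor compound 3 carries a number, so no step can be read for the change from phenyl to 3,5-dimethoxyphenyl. No supporting evidence bears on this result. The compounds shown leave open whether this change shifts cell toxicity at all.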